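A few compounds are considered here, and "the series" means these few. Any claim that something is new, unique, unknown or untested is made for them only; others in the source may bear on it.

Compound 1 `COc1ccc(-c2cc(/C=C/C(=O)c3ccc(N)cc3)[nH]n2)cc1` gives the lowest of the two numbers shown in a functional assay on NCI/ADR-RES cells (Homo sapiens) for inhibition, read by sulforhodamine B assay, with a stated time of 48 h (a lower number here means a stronger inhibitor of growth, a higher number a weaker inhibitor of growth), namely 15500 nM. Its nearest neighbour, compound 3 `COc1cc(-c2cc(/C=C/C(=O)c3ccc(F)c(F)c3)[nH]n2)cc(OC)c1OC`, gives 50500 nM. Compound 2 `COc1cc(-c2cc(/C=C/C(=O)c3ccc(Cl)c(Cl)c3)[nH]n2)cc(OC)c1OC` gives only a limit of the assay, > 100000 nM. Within the data shown here, the one measured step, an at least 1.9-fold lower number from compound 2 to compound 3 (0.29 log units; that floor lies within the scatter), concerns the ring on the carbonyl carbon, not the ring that changes here. Compound 4 `COc1ccc(-c2cc(/C=C/C(=O)c3ccc(N)cc3)[nH]n2)cc1OC` differs from compound 1 by methoxy in place of hydrogen on an aromatic carbon. Among the measured compounds shown here, no measured step bears on that change, so no shift beyond the scatter in this assay is expected, and the estimated step is a 1.2-fold higher number from compound 1 to compound 4 (0.06 log units; within the scatter). Compound 4 is therefore expected to give about 18000 nM, between 7000 nM and 50000 nM.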

Compound 4, concentration for total growth inhibition: > 100000 nM
Compound 4: no number, only a limit; the forecaster's own chance of this, stated with the estimate: 5%; middle value at least 5.5-fold (0.74 log units) from the limit.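

In this assay, adding methoxy on an aromatic carbon, ortho to a methoxy group and meta to a large group, gives an at least 6.4-fold higher number from compound 1 to compound 4 (0.80 log units; beyond the scatter). This is the first single change at this ring among the compounds shown, and it moves the result beyond the scatter. Compound 4 gives only a limit of the assay, so the step has a floor and no upper end: the limit of > 100000 nM in this assay, at which 2 of the 4 values shown sit.

From the compounds shown here alone, it remains open whether fluoro, hydroxy or ethoxy at this position would have the same outcome. Going by these compounds, it is also open whether methoxy does this with the 3,4-difluorophenyl on the carbonyl carbon.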